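The compounds below may be only part of what the source reports. "The series", "measured", "known", "first", "only" and "open" are said of these compounds alone.

In a functional assay on the whole organism (Ehrlich cells, Mus musculus) for antiproliferative activity, with a stated time of 24 h, at a dose of 0.2 mmol/kg by the intraperitoneal route (on this read-out higher numbers stand for more inhibition at the one dose given (going by the name of the read-out) and lower numbers for less inhibition), compound 3 `Nc1ccccc1NC(=O)c1ccc(NCC(=O)Nc2ccc([N+](=O)[O-])cc2)cc1` gives 77.5%, the highest of the three numbers here. Compound 2 `Nc1ccccc1NC(=O)CCCNCC(=O)Nc1cccc([N+](=O)[O-])c1` gives 36%, and compound 1 `Nc1ccccc1NC(=O)CCCNCC(=O)Nc1cccc(Cl)c1` gives 22.5%. Among the compounds with values here, the one measured step, a number 13.5 percentage points higher from compound 1 to compound 2 (beyond the scatter), replaces chloro with nitro on a different core, so it does not speak to moving a nitro group already present. Compound 4 `Nc1ccccc1NC(=O)c1ccc(NCC(=O)Nc2cccc([N+](=O)[O-])c2)cc1` keeps every atom of compound 3 and only rearranges them: 3-nitrophenyl in place of 4-nitrophenyl on an amide-type nitrogen. Within the data shown here, no measured pair shows such a positional change, so no direction is indicated, and a shift within the scatter is the plainest expectation. Because compound 3 gives 77.5%, the step of a number 7.5 percentage points lower from compound 3 to compound 4 (within the scatter) is expected to be small. Compound 4 is therefore estimated at 70%, between 50% and 88%.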

Compound 4, a percentage reported as inhibition, in the whole organism at one dose (the size of the read-out at that dose, not a potency): 40.4%
Compound 4: the middle estimate sits 29.6 percentage points above what was measured; measured number below the stated range.
By their numbers in this assay, from the lowest: compound 1; then compounds 2 and 4 (each within the scatter of the next); then compound 3.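

In this assay the place of the nitro group on the ring matters: the step of a number 37.1 percentage points lower from compound 3 to compound 4 (beyond the scatter) is large, yet 3-nitrophenyl and 4-nitrophenyl hold the same atoms. The earlier step swapped one group for another on a different core, whereas this one shows that moving a single group on an unchanged core can cost much of the inhibition. Nothing available here explains this drop. Still open, on these data alone, is whether 4-nitrophenyl would also outdo 3-nitrophenyl on the core of compound 2. Also open, as far as these compounds go, is how an amine or a carboxylic acid in place of the nitro group would fare.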